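The source may report more compounds than this note shows. Statements on the series, on what has been measured and on what is new or still open speak of the compounds shown alone.

Series of diaryl ureas carrying a bicyclic ring on the aniline side. In a functional assay on NCI-H460 cells (Homo sapiens) for cytotoxicity, read by MTT assay, with a stated time of 72 h (on this read-out lower numbers stand for stronger inhibition and higher numbers for weaker inhibition), compound 1 `O=C(Nc1ccc(-n2ncc3c(Cl)cccc32)cc1)Nc1ccc(Cl)c(C(F)(F)F)c1` gives 1300 nM. Among the measured compounds shown here, compound 2 `O=C(Nc1ccc(-n2ncc3ccncc32)cc1)Nc1ccc(Cl)c(C(F)(F)F)c1`, in this assay, gives 4800 nM, the higher of the two numbers so far; the only measured step, a 3.7-fold higher number from compound 1 to compound 2 (0.57 log units; beyond the scatter), replaces the chloro-bearing bicycle of compound 1 with a nitrogen-containing one and is modest but beyond the scatter. Compound 3 `O=C(Nc1ccc(-n2ncc3cccnc32)cc1)Nc1ccc(Cl)c(C(F)(F)F)c1` is the next member: relative to compound 2 the change is a group of 9 heavy atoms (6 carbon, 3 nitrogen; one five-membered aromatic ring with 2 hetero atoms, one six-membered aromatic ring with 1 hetero atom) in place of a group of 9 heavy atoms (6 carbon, 3 nitrogen; one five-membered aromatic ring with 2 hetero atoms, one six-membered aromatic ring with 1 hetero atom), on an aromatic carbon, so the two share the same atoms joined differently. For the measured compounds named here, no measured pair covers a shift of the ring nitrogen alone, and the step from compound 1 to compound 2 concerns a different kind of change, so it gives only a loose guide. Compound 3 is therefore expected to stay near compound 2, with a 1.2-fold lower number from compound 2 to compound 3 (0.08 log units; within the scatter) judged not clearly beyond the scatter in either direction. The estimate for compound 3 in this assay is 4000 nM, ranging from 1500 nM to 11000 nM.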

Compound 3, half-maximal inhibitory concentration: 16600 nM
Estimate against measurement, compound 3: 4.2-fold (0.62 log units) below; measured number above the stated range.
By their numbers in this assay, from the lowest: compound 1; then compound 2; then compound 3.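

In this assay, rejoining the same atoms within the bicycle is not a neutral change: a 3.5-fold higher number from compound 2 to compound 3 (0.54 log units; beyond the scatter), although the printed counts of heavy atoms, hydrogen-bond donors and hydrogen-bond acceptors are identical on both sides. The choice of nitrogen-containing bicycle therefore sets how much is given up relative to the chloro-bearing bicycle, with the exchange now reaching a large step, a 13-fold higher number from compound 1 to compound 3 (1.11 log units; beyond the scatter). No measurement at hand accounts for the difference between compound 2 and compound 3.

Still open, on these data alone, is how far the chlorine of compound 1 contributes on its own, and whether an amine or a methoxy group at that place on the bicycle would keep or lose its standing. The compounds shown also leave unsettled whether a chlorine on either nitrogen-containing bicycle would bring the number back down.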